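Swapping one ring on compounds at the assay limit

The compounds below may be only part of what the source reports. "The series", "measured", "known", "first", "only" and "open" are said of these compounds alone.

Compound 1 `Cc1ccc(-c2ccc3[nH]c(=O)nc(-c4ccccc4)c3c2)cn1`: > 50000 nM (a limit)
Compound 2 `O=c1nc(-c2ccccc2)c2cc(-c3cncnc3)ccc2[nH]1`: > 50000 nM (a limit)

Both entries come from an ADME assay on L6 cells (Rattus norvegicus) for cytotoxicity, read by fluorescence and resazurin assay, with a stated time of 72 h; a higher number here means that more compound is needed for the effect, a lower number that less compound is needed. Compound 2 stands at a limit of the assay, > 50000 nM, and not at a measured number. Compound 1 is also reported only as a limit, > 50000 nM. The record so far is short: the limit of > 50000 nM in this assay, at which 2 of the 2 values shown sit.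

Compound 3 `Cn1cc(-c2ccc3[nH]c(=O)nc(-c4ccccc4)c3c2)cn1` keeps the core of compound 2 and carries 1-methyl-1H-pyrazol-4-yl in place of pyrimidin-5-yl on an aromatic carbon.

Going by the values given here, one measured step bears on this change, since it exchanges the aromatic ring at the same place: a step that the two limits leave unreadable from compound 1 to compound 2. Its size cannot be read, as both of its ends are limits. Neither ring tried so far has given a number, so no clear step is expected in this assay. The estimated step is a step that the limit leaves unreadable from compound 2 to compound 3. For compound 3 the estimate is 60000 nM, with an expected range from 25000 nM to 100000 nM. The likeliest outcome is that the assay again reports only a limit.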

Compound 3, half-maximal effective concentration: > 50000 nM
Compound 3: only a limit was reported; the forecaster's own chance of this, stated with the estimate: 75%; the middle value is on the limit's open side.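

Compound 3 gives > 50000 nM in this assay, which is again a limit and not a number. The steps among compound 1, compound 2 and compound 3 therefore cannot be read. The compounds shown leave open what concentration any of these three rings on the shared core would need for the effect, as the record stands at: the limit of > 50000 nM in this assay, at which 3 of the 3 values shown sit.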